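This account rests on a few compounds, and the source may have more. Where it says the series, first, only, none or still open, it means among the compounds named here.

Measured compounds:
- Compound 1, `CC(C(=O)NCc1ccc(C(F)(F)F)cc1N1CCC(Cc2ccc(F)cc2)CC1)c1ccc(NS(C)(=O)=O)c(F)c1`, gives 0.4 nM in an assay on CHO cells for antagonist activity at transient receptor potential cation channel subfamily V member 1 (Homo sapiens), read by FLIPR; on this read-out lower numbers stand for stronger inhibition and higher numbers for weaker inhibition.
- Compound 2, `COc1ccc(N2CCN(c3cc(C(F)(F)F)ccc3CNC(=O)C(C)c3ccc(NS(C)(=O)=O)c(F)c3)CC2)cc1`, gives 1.6 nM in this assay.
- Compound 3, `CCCCCCSc1cc(C(F)(F)F)ccc1CNC(=O)C(C)c1ccc(NS(C)(=O)=O)c(F)c1`, gives 1.8 nM in this assay.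

Among these three numbers compound 3 has the highest. Its nearest neighbour is compound 2, whose number lies within the scatter of that of compound 3, so no order between them can be read. Compound 1 lies further away, with a number beyond the scatter below that of compound 3.

Compound 4, `COc1cc(OC)cc(-c2cc(C(F)(F)F)ccc2CNC(=O)C(C)c2ccc(NS(C)(=O)=O)c(F)c2)c1`, has not yet been measured in this assay. It differs from compound 3 in one place: 3,5-dimethoxyphenyl in place of hexylsulfanyl on an aromatic carbon. Compounds 1 and 2 carry ring-containing groups at this place. Compound 1 gives 0.4 nM. Compound 2 gives 1.6 nM. These two numbers give no clear lead on the size of any step. The step from compound 3 to compound 4 in this assay is therefore expected to be small, a 1.1-fold higher number from compound 3 to compound 4 (0.05 log units; within the scatter), and possibly within the scatter. Compound 4 is expected to give about 2 nM, between 0.5 nM and 8 nM.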

Compound 4, inhibition constant: 5.8 nM
Compound 4: middle estimate off by 2.9-fold (0.46 log units), on the low side; measured number inside the range.
By their numbers in this assay, from the lowest: compound 1; then compounds 2 and 3 (each within the scatter of the next); then compound 4.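

Among the compounds shown here, putting 3,5-dimethoxyphenyl in place of hexylsulfanyl on this aromatic carbon gives the first readable step at this place in this assay: a 3.2-fold higher number from compound 3 to compound 4 (0.51 log units; beyond the scatter). The step lies beyond the scatter, so the position does respond to a change of group, although the size of this response is modest and the direct swap of a sulfur-linked open chain for an aromatic ring leaves compound 4 with a weaker number than compound 3. No measurement at hand bears on what lies behind this step.

On these data alone, whether the step goes with the aromatic ring itself or with its two methoxy groups stays open, and a plain phenyl group would speak to that. As far as these compounds go, how a shorter chain such as butylsulfanyl or a small amine such as morpholine would stand against compound 3 at this carbon also stays open.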